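Dropping the Acetoxy Group from Compound 1

The compounds below may be only part of what the source reports. "The series", "measured", "known", "first", "only" and "open" are said of these compounds alone.

Compound 1 `CC(=O)OCc1ccc2oc(=O)c(C(=O)Oc3cccc(Cl)c3)cc2c1` gives the lowest number of the three compounds measured in a functional assay on HT-1080 cells (Homo sapiens), read by transwell migration, with a stated time of 24 h, tested at 10 uM (on this read-out lower numbers stand for a stronger effect and higher numbers for a weaker effect at the one concentration tested), namely 6.17% at the single concentration tested. Its nearest neighbour is compound 3 `CC(=O)OCc1ccc2oc(=O)c(C(=O)Sc3cccc(Br)c3)cc2c1`, which in this assay gives 67.8%, and the furthest is compound 2 `CC(=O)OCc1ccc2oc(=O)c(C(=O)Sc3ccccc3)cc2c1`, which gives 73.8% in the same assay. Both measured steps away from compound 1 are large: a number 67.6 percentage points higher from compound 1 to compound 2 (beyond the scatter) and a number 61.6 percentage points higher from compound 1 to compound 3 (beyond the scatter), each exchanging the 3-chlorophenoxy on the carbonyl carbon for a sulfanyl group. The third step, a number 6 percentage points lower from compound 2 to compound 3 (within the scatter), bromo in place of hydrogen on an aromatic carbon, lies within the scatter.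

Compound 4 `Cc1ccc2oc(=O)c(C(=O)Oc3cccc(Cl)c3)cc2c1` differs from compound 1 at a different place: hydrogen in place of acetoxy on a saturated chain carbon bound to an aromatic carbon. None of the three measured steps touches this position; all of them concern the group on the carbonyl carbon, which compound 4 keeps unchanged from compound 1. Among the measured compounds shown here, no measured step therefore bears directly on this change, and the expectation rests only on the 3-chlorophenoxy ester being retained. Compound 4 is expected to stay close to compound 1, with an estimated step of a number 13.8 percentage points higher from compound 1 to compound 4 (beyond the scatter), probably within or only modestly beyond the scatter. The estimate for compound 4 in this assay is 20%, within a range from 2% to 55%.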

Compound 4, a percentage reported as activity, at one concentration (the size of the read-out at that concentration, not a potency): 27.6%
Compound 4: the middle estimate sits 7.6 percentage points below what was measured; low and high end bracket the measured number.
By their numbers in this assay, from the lowest: compound 1; then compound 4; then compounds 3 and 2 (each within the scatter of the next).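

With the 3-chlorophenoxy group on the carbonyl carbon held fixed in this assay, hydrogen in place of acetoxy gives a number 21.4 percentage points higher from compound 1 to compound 4 (beyond the scatter), so this position has a real but modest effect on the read-out. This step is smaller than the large steps at the carbonyl carbon, a number 67.6 percentage points higher from compound 1 to compound 2 (beyond the scatter) and a number 61.6 percentage points higher from compound 1 to compound 3 (beyond the scatter), and compound 4, which has lost the acetoxy group and carries a methyl in place of the acetoxymethyl, still stands apart from both sulfanyl compounds in its printed value. Nothing in the available data accounts for the rise seen on removing the acetoxy group. The compounds shown leave open whether the acetoxy group itself matters or whether any other group on this carbon would serve as well, a question that a hydroxyl, an amine or a carboxylic acid there could help to answer. They also leave open whether acetoxymethyl to methyl would produce a step of similar size in a compound carrying phenylsulfanyl or (3-bromophenyl)sulfanyl on the carbonyl carbon.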